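The compounds below may be only part of what the source reports. "The series", "measured", "known", "first", "only" and "open" are said of these compounds alone.

Working notes on the series. Compound 1 `O=C(NCc1ccc(F)cc1)c1nc(Br)c2cccnc2c1NCCO` carries a (2-hydroxyethyl)amino group on the shared core. In a functional assay on HCT-116 cells (Homo sapiens) for cytotoxicity, read by MTT assay, with a stated time of 72 h (on this read-out lower numbers stand for stronger inhibition and higher numbers for weaker inhibition), compound 1 gives only a limit, > 20000 nM, and no number stands for it. Compound 2 `N[C@H]1CC[C@H](Nc2c(C(=O)NCc3cccs3)nc(Br)c3cccnc23)CC1` belongs to the same series but in this assay compound 2 has "not determined" (no result reported), so nothing can be said of its potency. Among the compounds with values here, compound 1 therefore sits at the limit of > 20000 nM in this assay, at which 1 of the 2 values shown sits, the only reading of any kind so far. Compound 3 `NCCCCCCNc1c(C(=O)NCc2ccc(F)cc2)nc(Br)c2cccnc12` is the next member to be measured, and it differs from compound 1 as follows: 4-aminobutyl in place of hydroxy on a saturated chain carbon, two bonds along the chain from a nitrogen on an aromatic ring. Within the data shown here, no measured step between two numbered values exists, so the expected size of the change in this assay is uncertain; the estimated step of an at least 2.0-fold lower number from compound 1 to compound 3 (0.30 log units; that floor lies within the scatter) points toward stronger inhibition but not clearly beyond the scatter from a limit. Compound 3 is thus expected to give 10000 nM in this assay, within 2000 nM to 40000 nM, with a fair chance that only a limit is again reported.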

Compound 3, half-maximal inhibitory concentration: 7000 nM
Compound 3: middle estimate off by 1.4-fold (0.15 log units), on the high side; the measured number falls inside the stated range.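

In this assay, within the data shown here, replacing the (2-hydroxyethyl)amino group with (6-aminohexyl)amino gives the first readable step, an at least 2.8-fold lower number from compound 1 to compound 3 (0.45 log units; beyond the scatter), and this step lies beyond the scatter. It sets only a minimum for the size of the change, because compound 1 gives only a limit: the limit of > 20000 nM in this assay, at which 1 of the 3 values shown sits. At this position, compound 3 also gives the first actual number, 7000 nM, so a measurable value can be obtained with a longer chain ending in an amine.

Chain length and end group change together here, so the compounds shown do not separate them; a (2-aminoethyl)amino group or an unsubstituted hexylamino chain would address that question. Among these compounds, compound 2 has no reported result, so no step involving it can be read.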